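Fluorophenyl on the Triazole: an Expected Modest Rise

A few compounds are considered here, and "the series" means these few. Any claim that something is new, unique, unknown or untested is made for them only; others in the source may bear on it.

Three compounds share one core. Compound 1 `CCOC(=O)c1cn(C(c2ccccc2)c2cc3cc(Br)ccc3nc2OC)nn1` carries an ethoxycarbonyl group on an aromatic carbon; in an ADME assay on SK-OV-3 cells (Homo sapiens) for cytotoxicity, read by sulforhodamine B assay, with a stated time of 48 h, tested at 10 uM (a higher number here means more inhibition at the concentration tested (going by the name of the read-out), a lower number less inhibition), compound 1 gives 2.01%, the lowest of the three numbers. Compound 2 `COc1nc2ccc(Br)cc2cc1C(c1ccccc1)n1cc(-c2ccc(OC(F)(F)F)cc2)nn1` gives 14.8%, and compound 3 `COc1nc2ccc(Br)cc2cc1C(c1ccccc1)n1cc(CO)nn1` gives 3.23%. The step of a number 12.8 percentage points higher from compound 1 to compound 2 (beyond the scatter) lies beyond the scatter, whereas a number 1.2 percentage points higher from compound 1 to compound 3 (within the scatter) stays within it. Compound 4 `COc1nc2ccc(Br)cc2cc1C(c1ccccc1)n1cc(-c2ccc(F)cc2)nn1` is not yet measured; its change from compound 1 is 4-fluorophenyl in place of ethoxycarbonyl on an aromatic carbon. This resembles the step to compound 2, where 4-(trifluoromethoxy)phenyl replaced the same ethoxycarbonyl, so a modest rise is expected, a number 8 percentage points higher from compound 1 to compound 4 (within the scatter). Compound 4 is therefore expected to give about 10% in this assay, within a range from 0% to 22%.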

Compound 4, a percentage reported as inhibition, at one concentration (the size of the read-out at that concentration, not a potency): 14.3%
Estimate against measurement, compound 4: 4.3 percentage points below; the measured number falls inside the stated range.
By their numbers in this assay, from the lowest: compounds 1 and 3 (each within the scatter of the next); then compounds 4 and 2 (each within the scatter of the next).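

In this assay, 4-fluorophenyl on this aromatic carbon gives a number 12.3 percentage points higher from compound 1 to compound 4 (beyond the scatter) and a number 11.1 percentage points higher from compound 3 to compound 4 (beyond the scatter), so the rise seen with 4-(trifluoromethoxy)phenyl is not confined to that one group. Changing the group on the added aromatic ring makes little difference, with a number 0.5 percentage points lower from compound 2 to compound 4 (within the scatter). No measurement here bears on the reason for these steps. The compounds shown leave open whether an unsubstituted phenyl on this carbon would give a similar number. Going by these compounds, how an amine or a carboxylic acid in this place would read is also open.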